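The compounds below may be only part of what the source reports. "The series", "measured", "known", "first", "only" and "open" are said of these compounds alone.

Compound 1, with the structure `CC1(C)CC(=O)C2=C(C1)NC(c1ccccc1)=CC2c1ccc([N+](=O)[O-])cc1`, was tested in an assay on isolated protein for inhibition of glucose-6-phosphatase catalytic subunit 1 (Homo sapiens), read by inositol phosphate accumulation, with a stated time of 30 min, tested at 100 uM (a higher number here means more inhibition at the concentration tested (going by the name of the read-out), a lower number less inhibition), and came out as "not active" (no number reported), so no number stands for it and it can only be placed at the weak end of what this series shows. Two other members of the same shared core give numbers. Compound 2, `COc1ccc(C2=CC(c3ccccc3)C3=C(CC(C)(C)CC3=O)N2)cc1`, shows 8.34% in this assay, and compound 3, `O=C1CCCC2=C1C(c1ccc(F)cc1)C=C(c1ccccc1)N2`, shows 21.9% in this assay. Neither value points to strong inhibition at the concentration used.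

Compound 4, `COc1ccc(C2C=C(c3ccccc3)NC3=C2C(=O)CC(C)(C)C3)cc1`, has not yet been measured. It differs from compound 1 in one place: methoxy in place of nitro on an aromatic carbon. Among the compounds with values here, since compound 1 carries no number, no step between these two compounds can be worked out, and nothing here says how this change behaves.

Given that compound 1 gave "not active" (no number reported) and that compound 2, which also carries the methoxyphenyl group, gave 8.34%, only a small movement in this assay is expected for compound 4, if any at all beyond the usual scatter. Compound 4 is therefore estimated to give 10% in this assay, expected to fall between 0% and 25%.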

Compound 4, a percentage reported as inhibition, at one concentration (the size of the read-out at that concentration, not a potency): "not active" (no number reported)
No number was reported for compound 4; the estimate stays without a comparison.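

In this assay, within the data shown here, compound 1 gives "not active" (no number reported) and compound 4 gives "not active" (no number reported) as well, and no step between these two compounds can be read. No supporting evidence bears on this result. The compounds shown leave open whether going from 4-nitrophenyl to 4-methoxyphenyl changes inhibition at all.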